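The compounds below may be only part of what the source reports. "The series", "measured", "known", "first", "only" and "open" are said of these compounds alone.

Measured in a functional assay on MIA PaCa-2 cells (Homo sapiens) for inhibition, read by MTT assay, with a stated time of 3 days; a higher number here means a weaker inhibitor, a lower number a stronger inhibitor:
- compound 1 `CCN(CC)S(=O)(=O)c1ccc(S(=O)(=O)N2CCC[C@@H](C(=O)N[C@H]3CC[C@H](OC)CC3)C2)cc1`: 2290 nM
- compound 2 `CCN(CC)S(=O)(=O)c1ccc(S(=O)(=O)N2CCC[C@@H](C(=O)N3CCC(O)CC3)C2)cc1`: 230 nM
- compound 3 `CCN(CC)S(=O)(=O)c1ccc(S(=O)(=O)N2CCC[C@@H](C(=O)N3CCOCC3)C2)cc1`: 160 nM

Compound 3 and compound 2 form the low pair of this small set, with a 1.4-fold lower number from compound 2 to compound 3 (0.16 log units; within the scatter), while the gap to the third member is a 14-fold lower number from compound 1 to compound 3 (1.16 log units; beyond the scatter). Compound 4 `CCN(CC)S(=O)(=O)c1ccc(S(=O)(=O)N2CCC[C@@H](C(=O)N[C@H]3CCOC3)C2)cc1` is the next structure, and its change from compound 3 is (oxolan-3-yl)amino in place of morpholin-4-yl on a carbonyl carbon. The closest evidence is compound 1, which also has a ring-bearing amino group on the carbonyl carbon and stands apart at 2290 nM. Its ring differs, however, so only part of that gap is expected to return in this assay. The expected step is a 4.4-fold higher number from compound 3 to compound 4 (0.64 log units; beyond the scatter). The estimated value for compound 4 is 700 nM, with an expected range of 220 nM to 2200 nM.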

Compound 4, half-maximal inhibitory concentration: 290 nM
Beside the measured number, compound 4's estimate is 2.4-fold (0.38 log units) above it; measured number inside the range.
By their numbers in this assay, from the lowest: compounds 3, 2 and 4 (each within the scatter of the next); then compound 1.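

In this assay, the swap to (oxolan-3-yl)amino shows that a hydrogen-bond donor on the amide-type nitrogen can sit with the low group, with a 1.8-fold higher number from compound 3 to compound 4 (0.26 log units; within the scatter) and a 1.3-fold higher number from compound 2 to compound 4 (0.10 log units; within the scatter). Compound 1 shares that donor, yet a 7.9-fold lower number from compound 1 to compound 4 (0.90 log units; beyond the scatter) with oxolan-3-yl in place of 4-methoxycyclohexyl, so the donor alone does not go with its high number. No supporting evidence explains these steps. As far as these compounds go, it remains open whether the ring or its methoxy group sets compound 1 apart, and whether a plain cyclohexyl group on that nitrogen would stay with the low group.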